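Three weak antiproliferative lactone ethers and a dicarbamoyl imidazole analogue

The source may report more compounds than this note shows. Statements on the series, on what has been measured and on what is new or still open speak of the compounds shown alone.

Three compounds have been examined in a functional assay on MCF7 cells (Homo sapiens) for antiproliferative activity, read by MTT assay, with a stated time of 72 h; a higher number here means a weaker inhibitor, a lower number a stronger inhibitor. Compound 1 `N#Cc1ncn(C/C=C2\OC(=O)C(OCc3ccccc3)=C2OCc2ccccc2)c1C#N` gives 63000 nM in this assay, compound 2 `COC(=O)c1ncn(CC=C2OC(=O)C(OCc3ccccc3)=C2OCc2ccccc2)c1C(=O)OC` gives 52000 nM, and compound 3 `NC(=O)c1ncn(CCC2(O)NC(=O)C(OCc3ccccc3)=C2OCc2ccccc2)n1` gives 61000 nM. Compound 3 thus has the second highest of the three numbers, but its gap to compound 1 and its gap to compound 2 both lie within the usual scatter, so the three values cannot be told apart; none of them is called stronger or weaker than another.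

Compound 4 `NC(=O)c1ncn(CCC2(O)NC(=O)C(OCc3ccccc3)=C2OCc2ccccc2)c1C(N)=O` has not yet been measured. It differs from compound 3 in one place: 4,5-dicarbamoyl-1H-imidazol-1-yl in place of 3-carbamoyl-1H-1,2,4-triazol-1-yl on a saturated chain carbon, two bonds along the chain from a saturated ring carbon. For the measured compounds named here, no pair of measured compounds differs in only one place, so nothing in the data shows what a change of this kind does to the read-out. All three measured values sit close together, which gives no ground for expecting movement in either direction. The step from compound 3 to compound 4 is therefore estimated as a 1.1-fold lower number from compound 3 to compound 4 (0.04 log units; within the scatter), none beyond the scatter. In this assay compound 4 is expected to give 55000 nM, with a range from 25000 nM to 120000 nM.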

Compound 4, half-maximal inhibitory concentration: > 100000 nM
Compound 4: no number, only a limit; the forecaster's own chance of this, stated with the estimate: 15%; middle value at least 1.8-fold (0.25 log units) from the limit.
By their numbers in this assay, from the lowest: compounds 2, 3 and 1 (each within the scatter of the next). At a limit, above all of these: compound 4.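

In this assay compound 4 gives > 100000 nM, a limit of the assay and not a number. This is the only one-place change shown, on a saturated chain carbon, two bonds along the chain from a saturated ring carbon, and replacing 3-carbamoyl-1H-1,2,4-triazol-1-yl with 4,5-dicarbamoyl-1H-imidazol-1-yl gives an at least 1.6-fold higher number from compound 3 to compound 4 (0.21 log units; that floor lies within the scatter), so the change brings no lower number, while the true size of the step stays unknown. Compound 4 is alone among the compounds shown in sitting at this limit: the limit of > 100000 nM in this assay, at which 1 of the 4 values shown sits.

The ring and the number of carbamoyl groups change together in this step, and the compounds shown do not separate the two, as an imidazolyl group bearing a single carbamoyl might. As far as these compounds go, whether a carboxylic acid, an amine or a longer chain at this place would give a lower number also stays open.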